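The source may hold more compounds than are shown below. What is called first, only, known or untested is meant among the compounds shown, and "the series" means these compounds.

Measured compounds so far:

- compound 1, `CCCCS(=O)(=O)NNC(=O)[C@@H](NC(=O)c1cccc(Cn2ccnc2)c1)[C@@H](C)CC`: "not determined" (no result reported)
- compound 2, `CC[C@H](C)[C@H](NC(=O)c1cccc(Cn2ccnc2)c1)C(=O)NNC(=O)OC(C)(C)C`: "not determined" (no result reported)
- compound 3, `CC[C@H](C)[C@H](NC(=O)c1cccc(Cn2ccnc2)c1)C(=O)NNS(=O)(=O)c1ccc(OC)cc1`: 3%

For the measured compounds named here, in an assay on HEK293 cells for displacement of a labelled ligand from Type-2 angiotensin II receptor (Homo sapiens), tested at 1 uM (a lower number here means a weaker effect, a higher number a stronger effect of the compound at the concentration tested), compound 3 gives 3%; that is the only number in the set. Going by the values given here, compound 1 and compound 2 carry no result in this assay, so compound 2 stands without a number of its own, and no step between measured compounds can be drawn. Compound 2 is therefore placed only by its structure, which shares the core of compound 3 and differs in the group on the terminal amide-type nitrogen.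

Compound 4, `CC[C@H](C)[C@H](NC(=O)c1cccc(Cn2ccnc2)c1)C(=O)NC#N`, is the next member to be measured. It differs from compound 2 as follows:

cyano in place of (tert-butoxycarbonyl)amino on an amide-type nitrogen

Among the compounds with values here, no step is recorded that would anchor this change. Within the data shown here, the only reading in this assay, from compound 3, sits at the bottom of the scale, and nothing among the measured compounds points to a large effect for the shared core at the tested concentration. Among the measured compounds shown here, for compound 4, a reading near that of compound 3 is therefore expected, within the scatter of the one number available and with no direction beyond it.

Compound 4 is estimated at 5%, with a range of -8% to 20% in this assay.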

Compound 4, a percentage reported as inhibition, at one concentration (the size of the read-out at that concentration, not a potency): 6%
Estimate against measurement, compound 4: 1 percentage points below, and the stated range covers the measured number.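

In this assay, for the compounds shown here, compound 4 gives 6% while compound 2 has no single number, so no step between compound 2 and compound 4 can be read. No further data bear on this result. The compounds shown leave open whether cyano in place of (tert-butoxycarbonyl)amino changes the read-out at all.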